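The source may report more compounds than this note shows. Statements on the series, on what has been measured and on what is new or still open speak of the compounds shown alone.

In a functional assay on NCI-H460 cells (Homo sapiens) for cytotoxicity, read by MTT assay, with a stated time of 48 h (a higher number here means a weaker inhibitor, a lower number a stronger inhibitor), compound 1 (`COc1cc(/C=C/C(=O)/C=C/c2nc3cc([N+](=O)[O-])ccc3n2C)ccc1O`) gives 6700 nM and compound 2 (`COc1cc(/C=C/C(=O)/C=C/c2nc3cc(O)ccc3n2C)ccc1O`) gives 7600 nM. Going by the values given here, these are the only two numbers so far, and they lie within the scatter of each other, so compound 1 does not stand apart from compound 2. Compound 3 (`COc1ccc(/C=C/C(=O)/C=C/c2nc3cc([N+](=O)[O-])ccc3n2C)cc1O`) has the same atoms as compound 1, joined differently: 3-hydroxy-4-methoxyphenyl in place of 4-hydroxy-3-methoxyphenyl on a double-bonded chain carbon bound to a double-bonded chain carbon. The hydroxy and methoxy groups trade places, while the rest of the molecule stays the same. Among the compounds with values here, the one measured step, a 1.1-fold higher number from compound 1 to compound 2 (0.05 log units; within the scatter), changes a different group, so it bears on this swap only indirectly. It does show that replacing nitro with hydroxy left the number within the scatter. No step beyond the scatter is therefore expected in this assay, though direct evidence is lacking. The expected result is a 1.0-fold higher number from compound 1 to compound 3 (0.02 log units; within the scatter). For compound 3 the estimated value is 7000 nM, with an expected range from 3000 nM to 16000 nM.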

Compound 3, half-maximal inhibitory concentration: 10500 nM
Compound 3: middle estimate off by 1.5-fold (0.18 log units), on the low side; the measured number falls inside the stated range.
By their numbers in this assay, from the lowest: compounds 1, 2 and 3 (each within the scatter of the next).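

In this assay, going by these compounds alone, trading 4-hydroxy-3-methoxyphenyl for 3-hydroxy-4-methoxyphenyl gives a 1.6-fold higher number from compound 1 to compound 3 (0.20 log units; within the scatter), the first measured change at this place on a double-bonded chain carbon bound to a double-bonded chain carbon. Exchanging the hydroxy and methoxy groups therefore leaves the number within the usual scatter, just as the step on the nitro group did at a different place, a 1.1-fold higher number from compound 1 to compound 2 (0.05 log units; within the scatter). Nothing shown here offers an explanation for the size of this step.

From the compounds shown here alone, it remains open whether an amine, a carboxylic acid or a longer chain such as ethoxy in place of the hydroxy or methoxy group would move the number beyond the scatter. Going by these compounds, it is also open whether the same exchange would give a similar step when hydroxy replaces nitro, as in compound 2.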